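This account rests on a few compounds, and the source may have more. Where it says the series, first, only, none or still open, it means among the compounds named here.

Compound 1 `Cn1cnc(CN2CCN(c3cccc4[nH]c(-c5ccc(C(C)(C)C)cc5)nc34)CC2)c1` is a member of a small set of compounds sharing one core, tested in an assay on isolated protein for displacement of a labelled ligand from Gonadotropin-releasing hormone receptor (Homo sapiens); on this read-out higher numbers stand for weaker inhibition and lower numbers for stronger inhibition. In this assay, for the measured compounds named here, compound 1 gives 33 nM, the highest of the two numbers measured so far. Going by the values given here, its only measured neighbour is compound 2 `CCc1nc(C)c(CN2CCN(c3cccc4[nH]c(-c5ccc(C(C)(C)C)cc5)nc34)CC2)s1`, which carries a 2-ethyl-4-methyl-1,3-thiazol-5-yl group in place of the 1-methyl-1H-imidazol-4-yl group of compound 1, on a saturated chain carbon bound to an amine nitrogen in a ring; in this assay compound 2 gives 20 nM. That single measured step is a 1.7-fold lower number from compound 1 to compound 2 (0.22 log units; within the scatter), so swapping one five-membered aromatic ring for another at this place has left the number essentially unchanged.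

Compound 3 `CCc1cc(CN2CCN(c3cccc4[nH]c(-c5ccc(C(C)(C)C)cc5)nc34)CC2)nn1C` has not yet been measured. It differs from compound 1 in the same place: 5-ethyl-1-methyl-1H-pyrazol-3-yl in place of 1-methyl-1H-imidazol-4-yl on a saturated chain carbon bound to an amine nitrogen in a ring. Among the compounds with values here, because the only comparable step, a 1.7-fold lower number from compound 1 to compound 2 (0.22 log units; within the scatter), stayed inside the scatter, the expectation for compound 3 is a number close to that of compound 1, with no step beyond the scatter in either direction, which means an expected step of a 1.2-fold lower number from compound 1 to compound 3 (0.09 log units; within the scatter). The estimated value for compound 3 in this assay is therefore 27 nM, with a range from 10 nM to 75 nM.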

Compound 3, half-maximal inhibitory concentration: 43 nM
For compound 3 the middle estimate is 1.6-fold (0.20 log units) below the measured one; the measured number falls inside the stated range.
By their numbers in this assay, from the lowest: compounds 2, 1 and 3 (each within the scatter of the next, the first and the last beyond it).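

In this assay, the step of a 1.3-fold higher number from compound 1 to compound 3 (0.11 log units; within the scatter) shows that 5-ethyl-1-methyl-1H-pyrazol-3-yl, which has more heavy atoms than 1-methyl-1H-imidazol-4-yl, can stand on a saturated chain carbon bound to an amine nitrogen in a ring while the number stays within the scatter. For the compounds shown here, the step of a 2.2-fold higher number from compound 2 to compound 3 (0.33 log units; beyond the scatter) is the first in this small set to go beyond the scatter, so the choice between two ethyl-bearing five-membered aromatic rings does register at this position, though only modestly, and compound 1 lies within the scatter of both compound 2 and compound 3. Nothing available explains this small difference.

As far as these compounds go, all three compounds carry a five-membered aromatic ring here, so it remains open how the number would respond to a six-membered ring such as pyridine, to a simple alkyl chain, or to a carboxylic acid at this place. It also remains open which feature of the change from 2-ethyl-4-methyl-1,3-thiazol-5-yl to 5-ethyl-1-methyl-1H-pyrazol-3-yl accounts for the step, since the ring and its substituents differ together.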